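From methoxy to ethoxy on the shared core

A few compounds are considered here, and "the series" means these few. Any claim that something is new, unique, unknown or untested is made for them only; others in the source may bear on it.

Among the measured compounds shown here, in a functional assay on MCF7 cells (Homo sapiens) for cytotoxicity, read by MTT assay, with a stated time of 72 h (on this read-out lower numbers stand for stronger inhibition and higher numbers for weaker inhibition), compound 1 (`CNc1cc2nc(-c3ccccc3)nn(-c3ccccc3)c-2cc1=O`) gives 690 nM, the only true number in the set. Compound 2 (`CC(=O)Nc1cc2nc(-c3ccccc3)nn(-c3ccccc3)c-2cc1=O`) gives > 5000 nM, which is a limit of the assay. Compound 3 (`COc1cc2nc(-c3ccccc3)nn(-c3ccccc3)c-2cc1=O`) gives > 5000 nM, which is also a limit and not a number. Compounds 2 and 3 therefore both stand at the limit of > 5000 nM in this assay, at which 2 of the 3 values shown sit, and a step that the two limits leave unreadable from compound 2 to compound 3 cannot be sized.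

Compound 4 (`CCOc1cc2nc(-c3ccccc3)nn(-c3ccccc3)c-2cc1=O`) is not yet measured. It carries ethoxy where compound 3 carries methoxy, with methyl in place of hydrogen on a saturated chain carbon bound to an oxygen on an aromatic ring.

For the measured compounds named here, no measured step tests this change directly. The nearest evidence is an at least 7.2-fold higher number from compound 1 to compound 3 (0.86 log units; beyond the scatter), with methoxy in place of methylamino, and an at least 7.2-fold higher number from compound 1 to compound 2 (0.86 log units; beyond the scatter), with acetyl in place of methyl on a nitrogen. Both show weaker inhibition once the methylamino group is gone or acylated, and neither gives any sign that an oxygen-linked group restores it. From the weak position of compound 3 after an at least 7.2-fold higher number from compound 1 to compound 3 (0.86 log units; beyond the scatter), no change beyond the scatter is expected in this assay. The expected step is a step that the limit leaves unreadable from compound 3 to compound 4, and its direction cannot be firmly set against a limit. For compound 4 the estimated value is 7000 nM, expected within a range from 2500 nM to 20000 nM, and most likely reported only as a limit.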

Compound 4, half-maximal inhibitory concentration: > 5000 nM
Compound 4 ended at the assay's limit; the forecaster's own chance of this, stated with the estimate: 80%; the middle value does not contradict the limit.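

In this assay compound 4 gives > 5000 nM, a limit and not a number, so methyl in place of hydrogen on a saturated chain carbon bound to an oxygen on an aromatic ring brings no measurable value at this position. Replacing the methylamino group with ethoxy gives an at least 7.2-fold higher number from compound 1 to compound 4 (0.86 log units; beyond the scatter), so a second oxygen-linked group, not only methoxy, fails to keep the measured value of compound 1. The steps to compound 4 from compound 3 and from compound 2 cannot be read, because all three compounds sit at the same limit: the limit of > 5000 nM in this assay, at which 3 of the 4 values shown sit.

As far as these compounds go, how far compound 2, compound 3 and compound 4 lie beyond that limit stays open, and with it any real difference between methoxy and ethoxy. Also open, from the compounds shown here alone, is whether a free amine, an ethylamino group or a dimethylamino group at this position would hold, improve or lose the activity seen for compound 1 at 690 nM in this assay.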